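Methoxy for Acetyl: Expected Shift in Cell Inhibition

The source may hold more compounds than are shown below. What is called first, only, known or untested is meant among the compounds shown, and "the series" means these compounds.

Three compounds have been measured in a functional assay on HeLa cells (Homo sapiens) for inhibition, read by CCK-8 assay, with a stated time of 48 h; a higher number here means a weaker inhibitor, a lower number a stronger inhibitor:
Compound 1, `Cn1ccc2cc(-c3cc4nccc(-c5ccc(F)cc5)n4n3)ccc21` — compound 1 gives 5210 nM.
Compound 2, `COc1cc(-c2ccnc3cc(-c4ccc(C(C)=O)cc4)nn23)cc(OC)c1OC` — compound 2 gives 1810 nM.
Compound 3, `COc1cc(-c2cc3nccc(-c4c[nH]c5ccccc45)n3n2)cc(OC)c1OC` — compound 3 reaches only > 10000 nM, which is a limit of the assay and not a number.

Among the two plain numbers in this assay , compound 2 stands lowest; compound 1 sits noticeably higher, and the gap between them lies beyond the usual scatter. Compound 3 is known only by its limit (the limit of > 10000 nM in this assay, at which 1 of the 3 values shown sits).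

The account now turns to compound 4, `COc1ccc(-c2cc3nccc(-c4cc(OC)c(OC)c(OC)c4)n3n2)cc1`, which has not yet been measured in this assay . Set against compound 2, the difference is methoxy in place of acetyl on an aromatic carbon. Both compounds keep the trimethoxyphenyl on the shared core and differ only in the group on the other phenyl ring: an acetyl in compound 2, a methoxy in compound 4.

Going by the values given here, no step between measured compounds bears on this exchange, so the expectation rests on compound 2 alone. The expected step of a 1.9-fold higher number from compound 2 to compound 4 (0.29 log units; within the scatter) is a move toward a weaker inhibitor, small enough that it might still fall within the scatter. On that basis compound 4 is expected near 3500 nM, within a range from 1200 nM to 10000 nM.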

Compound 4, half-maximal inhibitory concentration: 373 nM
Beside the measured number, compound 4's estimate is 9.4-fold (0.97 log units) above it; the whole stated range lies above it.
By their numbers in this assay, from the lowest: compound 4; then compound 2; then compound 1. At a limit, above all of these: compound 3.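

In this assay, the exchange of acetyl for methoxy on the aromatic ring, para to a large group, gives a 4.9-fold lower number from compound 2 to compound 4 (0.69 log units; beyond the scatter), with the trimethoxyphenyl and the shared core left unchanged. Going by these compounds alone, this is the first measured step between two compounds that differ in one place, and it shows that the group at this position can by itself move the number beyond the usual scatter: here the 4-methoxyphenyl compound reads as the stronger inhibitor of the pair than the 4-acetylphenyl compound. Nothing measured in this account speaks to what lies behind the step, which for now remains a single observation in one cell assay.

What the compounds shown leave open is whether the methoxy is itself favourable or whether the acetyl simply stands in the way, a question that a hydroxyl, an amine, a carboxylic acid or a longer chain such as ethoxy at the same place could help to settle. Also open, going by these compounds, is whether the exchange would act the same way on a compound that carries something other than the trimethoxyphenyl on the shared core.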